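The source may hold more compounds than are shown below. What is called first, only, known or untested is meant among the compounds shown, and "the series" means these compounds.

In an assay for inhibition of HSP60/HSP10 (Homo sapiens), with a stated time of 60 min (a lower number here means a stronger inhibitor, a higher number a weaker inhibitor), compound 2 `COc1c(Br)cccc1C(=O)Nc1ccccc1` gives only a limit, > 100000 nM, and not a number. Compound 1 `O=C(Nc1ccccc1)c1cc(Br)ccc1O` likewise gives only a limit in this assay, > 100000 nM. Everything measured so far thus sits at the limit of > 100000 nM in this assay, at which 2 of the 2 values shown sit. Compound 3 `O=C(Nc1ccccc1)c1cccc(Br)c1` differs from compound 2 by hydrogen in place of methoxy on an aromatic carbon, in words hydrogen in place of methoxy on an aromatic carbon. Going by the values given here, no measured pair shows this change, so its direction is open; since both known values rest at the limit, only a large gain would bring compound 3 into the measurable range. Compound 3 is estimated at 150000 nM, within a range from 40000 nM to 600000 nM. The expected step that the limit leaves unreadable from compound 2 to compound 3 is none beyond the scatter.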

Compound 3, half-maximal inhibitory concentration: > 100000 nM
Compound 3 was reported as a limit; the forecaster's own chance of this, stated with the estimate: 85%; the middle value does not contradict the limit.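

No step can be read from compound 2 to compound 3 or from compound 1 to compound 3, since all three compounds give only a limit in this assay: the limit of > 100000 nM in this assay, at which 3 of the 3 values shown sit.

These compounds leave open whether hydrogen, methoxy or hydroxy changes the strength of inhibition at all.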